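The source may report more compounds than this note shows. Statements on the series, on what has been measured and on what is new or still open speak of the compounds shown alone.

Three compounds have been measured in a functional assay on cells (Lymphocyte); a lower number here means a stronger inhibitor, a higher number a weaker inhibitor:

Compound 1, `O=C(COc1ccc(Cl)cc1)N1CCN(c2ncnc3sc(F)cc23)CC1`, gives 6350 nM.
Compound 2, `CCOC(=O)c1nc(N2CCN(C(=O)COc3ccc(Cl)cc3)CC2)c2cc(F)sc2n1`, gives only a limit of the assay, > 10000 nM.
Compound 3, `O=C(O)c1nc(N2CCN(C(=O)COc3ccc(Cl)cc3)CC2)c2cc(F)sc2n1`, gives only a limit of the assay as well, > 10000 nM.

Compound 3 therefore stands at the top of what this assay can report, at the limit of > 10000 nM in this assay, at which 2 of the 3 values shown sit. Only compound 1 yields an actual number, and the two steps away from it, an at least 1.5-fold higher number from compound 1 to compound 2 (0.19 log units; that floor lies within the scatter) and an at least 1.5-fold higher number from compound 1 to compound 3 (0.19 log units; that floor lies within the scatter), each give only a floor that lies within the scatter. The remaining pair, a step that the two limits leave unreadable from compound 2 to compound 3, gives no readable size at all, since both ends are limits.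

Compound 4, `NC(=O)c1nc(N2CCN(C(=O)COc3ccc(Cl)cc3)CC2)c2cc(F)sc2n1`, differs from compound 3 in a single place: amino in place of hydroxy on a carbonyl carbon. Among the compounds with values here, no measured step exchanges carboxy for carbamoyl, so the nearest guide is the unreadable pair just described, together with the fact that every compound carrying a group at this aromatic carbon has so far sat at the limit. No step beyond the scatter is expected in this assay, in either direction. Compound 4 is accordingly estimated at 15000 nM, with a range from 4000 nM to 50000 nM, and most likely reported again only as a limit. That estimate means a step that the limit leaves unreadable from compound 3 to compound 4, a step expected to stay within the scatter.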

Compound 4, half-maximal inhibitory concentration: > 10000 nM
Compound 4 gave a limit, no number (the forecaster's own chance of this, stated with the estimate: 70%); the middle value is on the limit's open side.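

With carbamoyl, a third group on this aromatic carbon, compound 2, compound 3 and compound 4 all read the same way in this assay: the limit of > 10000 nM in this assay, at which 3 of the 4 values shown sit.

Measured against the one compound with an actual number, the result is an at least 1.5-fold higher number from compound 1 to compound 4 (0.19 log units; that floor lies within the scatter), which means that a real loss of activity from adding carbamoyl is not shown. The steps among compound 2, compound 3 and compound 4 cannot be read, with a limit at both ends, and the exchange of hydroxy for amino on a carbonyl carbon therefore has no size that can be stated.

As far as these compounds go, whether any group at this aromatic carbon truly weakens inhibition remains open, and so does any ranking of ethoxycarbonyl, carboxy and carbamoyl, as none of the three has a number in this assay. From the compounds shown here alone, it is also open how a methyl group, an amine or a nitrile on this same carbon would read, and whether any of them would give a value that can be compared with compound 1.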